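Swapping a methylamino for a methylpyridinyloxy group

This account rests on a few compounds, and the source may have more. Where it says the series, first, only, none or still open, it means among the compounds named here.

Compound 2 `CNc1ccc(-c2ccn(CCC(C)C)c(=O)c2C#N)cc1` is one of two measured compounds in a functional assay on CHO cells for positive allosteric modulation of metabotropic glutamate receptor 2 (Homo sapiens), read by scintillation counting and GTPgammaS binding, with a stated time of 30 min; a lower number here means that less compound is needed, a higher number that more compound is needed for the effect. In this assay, within the data shown here, compound 2 gives 460 nM, the lowest of the two numbers, and its only neighbour is compound 1 `CC(C)CCn1ccc(-c2ccc(Oc3cccnc3)cc2)c(C#N)c1=O`, which gives 479 nM; these two values lie within the usual scatter of each other, so neither can be called the stronger. Among the measured compounds shown here, the one measured step, a 1.0-fold lower number from compound 1 to compound 2 (0.02 log units; within the scatter), shows that trading a pyridinyloxy group for a methylamino group on the same aromatic carbon changed nothing beyond the noise.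

Compound 3 `Cc1cc(Oc2ccc(-c3ccn(CCC(C)C)c(=O)c3C#N)cc2)ccn1` has not been measured. It differs from compound 2 in one place: (2-methylpyridin-4-yl)oxy in place of methylamino on an aromatic carbon. For the measured compounds named here, this change runs in the opposite sense to the measured step, a methylamino leaving and an aryloxy group entering, and the ring that enters carries one more methyl group than the one in compound 1. Because a 1.0-fold lower number from compound 1 to compound 2 (0.02 log units; within the scatter) was flat, the step of a 1.0-fold higher number from compound 2 to compound 3 (0.01 log units; within the scatter) is expected to stay within the scatter as well. Compound 3 is therefore estimated to give 470 nM, with a likely range from 200 nM to 1100 nM.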

Compound 3, half-maximal effective concentration: 447 nM
The estimate for compound 3 lay 1.1-fold (0.02 log units) above the measured number; the measured number falls inside the stated range.
By their numbers in this assay, from the lowest: compounds 3, 2 and 1 (each within the scatter of the next).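

Replacing methylamino with (2-methylpyridin-4-yl)oxy in this assay brings in more heavy atoms and a six-membered aromatic ring on the same aromatic carbon, yet the result is a 1.0-fold lower number from compound 2 to compound 3 (0.01 log units; within the scatter). A larger group carrying a ring is therefore accommodated at this place, para to a large group, without a change that can be told from the scatter. The comparison among the aryloxy groups reads the same way, since 2-methylpyridin-4-yl in place of pyridin-3-yl on the oxygen gives a 1.1-fold lower number from compound 1 to compound 3 (0.03 log units; within the scatter), but no measured property or other supporting data bears on why these groups read alike.

As far as these compounds go, whether a plain hydrogen, a carboxylic acid or a primary amine on this aromatic carbon would also stay within the scatter remains open. All the steps shown here are flat in this assay, so the compounds leave open which changes at this place, or elsewhere on the shared core, would move the number at all.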